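The compounds below may be only part of what the source reports. "The series", "measured", "known", "first", "only" and "open" are said of these compounds alone.

Of the compounds shown here, three sharing one core have been tested in a functional assay (aorta) for inhibition, with Rattus norvegicus as the target; on this read-out higher numbers stand for an effect only at larger amounts of compound and lower numbers for an effect already at smaller amounts. Compound 1 `O=C1C(Nc2ccc(F)cc2)=CC(=O)c2ncccc21` gives 541 nM. Compound 2 `O=C1C(Nc2cccc(F)c2)=CC(=O)c2ncccc21` gives 805 nM; how its core differs from that of compound 1 is not broken down here. Compound 3 `O=C1C(Nc2cc(F)cc(F)c2)=CC(=O)c2ncccc21` gives 449 nM. From compound 2 to compound 3 the change is fluoro in place of hydrogen on an aromatic carbon and it brought a 1.8-fold lower number from compound 2 to compound 3 (0.25 log units; within the scatter). Compound 4 `O=C1C(Nc2ccc(F)cc2F)=CC(=O)c2ncccc21` has not yet been measured; from compound 1 it differs by fluoro in place of hydrogen on an aromatic carbon, the same kind of change, but here the entering fluoro sits ortho to a large group and meta to a fluoro group, whereas in compound 3 it sits meta to a fluoro group and meta to a large group. For compound 4 a step of a 1.4-fold lower number from compound 1 to compound 4 (0.13 log units; within the scatter) is expected because a 1.8-fold lower number from compound 2 to compound 3 (0.25 log units; within the scatter) stayed within the scatter. Compound 4 is therefore estimated at 400 nM, between 180 nM and 900 nM.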

Compound 4, half-maximal effective concentration: 288 nM
Compound 4: the middle estimate sits 1.4-fold (0.14 log units) above what was measured; low and high end bracket the measured number.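

Putting fluoro in place of hydrogen on an aromatic carbon brought a 1.9-fold lower number from compound 1 to compound 4 (0.27 log units; within the scatter). Set beside the earlier case, the same change gave steps of matching size on the two cores: the same change on two cores in this assay, a 1.8-fold lower number (0.25 log units; within the scatter) from compound 2 to compound 3 and a 1.9-fold lower number (0.27 log units; within the scatter) from compound 1 to compound 4, 1.0-fold (0.02 log units) apart, within the scatter of two such steps. This does not show a real effect of the fluoro: each step on its own lies within the scatter, and two cores are too few to predict the result on a further core.

The compounds shown leave open whether a different group in this place, such as a chlorine atom, a methoxy group or an amine, would move the number beyond the scatter. They also leave open whether the match between the two steps would hold for a larger change.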